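The compounds below may be only part of what the source reports. "The series", "measured", "known", "first", "only" and "open" are said of these compounds alone.

The measured compounds are:

Compound 1, `CC1(C)[C@H]2CC[C@]1(C)N(Cc1cn(-c3cccc(F)c3)nn1)C(=O)C2`, 220 nM
Compound 2, `CC1(C)[C@H]2CC[C@]1(C)N(Cc1cn(-c3ccccc3C#N)nn1)C(=O)C2`, 240 nM
Compound 3, `CC1(C)[C@H]2CC[C@]1(C)N(Cc1cn(-c3ccc(F)cc3)nn1)C(=O)C2`, 110 nM

All three were examined in a functional assay on PANC-1 cells (Homo sapiens) for inhibition, read by MTT assay, with a stated time of 24 h; a lower number here means a stronger inhibitor, a higher number a weaker inhibitor. Compound 1 stands second highest of the three numbers: its nearest neighbour is compound 2, reached by a 1.1-fold higher number from compound 1 to compound 2 (0.04 log units; within the scatter), and its furthest is compound 3, reached by a 2.0-fold lower number from compound 1 to compound 3 (0.30 log units; within the scatter). Compound 4, `CC1(C)[C@H]2CC[C@]1(C)N(Cc1cn(-c3cccc(Br)c3)nn1)C(=O)C2`, has not yet been measured. It differs from compound 1 in one place: bromo in place of fluoro on an aromatic carbon.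

Going by the values given here, no measured step exchanges one halogen for another on the aryl group, so none bears directly on this change. What the measured steps do show is that varying the aryl substituent moves the number only a little: a 1.1-fold higher number from compound 1 to compound 2 (0.04 log units; within the scatter) and a 2.2-fold lower number from compound 2 to compound 3 (0.34 log units; beyond the scatter) are the largest movements, and only the latter edges beyond the scatter. On that basis a step within the scatter is expected from compound 1 to compound 4, with no confident direction. The estimate for compound 4 is 200 nM, between 90 nM and 450 nM, which corresponds to an expected 1.1-fold lower number from compound 1 to compound 4 (0.04 log units; within the scatter).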

Compound 4, half-maximal inhibitory concentration: 90 nM
Estimate against measurement, compound 4: 2.2-fold (0.35 log units) above, and the stated range covers the measured number.
By their numbers in this assay, from the lowest: compounds 4, 3, 1 and 2 (each within the scatter of the next, the first and the last beyond it).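

In this assay, going by these compounds alone, bromo in place of fluoro on this aromatic carbon gives a 2.4-fold lower number from compound 1 to compound 4 (0.39 log units; beyond the scatter), the first step from compound 1 to lie beyond the scatter and the first exchange of one halogen for another on the aryl group. The 3-bromophenyl group also separates from the 2-cyanophenyl group, with a 2.7-fold lower number from compound 2 to compound 4 (0.43 log units; beyond the scatter) beyond the scatter, yet it stays within the scatter of the 4-fluorophenyl group, with a 1.2-fold lower number from compound 3 to compound 4 (0.09 log units; within the scatter) leaving compounds 3 and 4 unresolved. Nothing available explains why this exchange moves the number.

With a single halogen exchange shown, it remains open whether bromo gives a similar step on other aryl groups. Going by these compounds, how chloro, an amine or a carboxylic acid would read on the same aromatic carbon also remains open.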